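The compounds below may be only part of what the source reports. "The series", "measured", "known", "first", "only" and "open" are said of these compounds alone.

Three compounds have been measured in a physicochemical assay for acid dissociation:

compound 1 `O=S(=O)(Nc1ccccc1)c1ccc(Cl)cc1` gives 8.47
compound 2 `O=S(=O)(Nc1ccccc1)c1ccc(Br)cc1` gives 8.5
compound 3 `O=[N+]([O-])c1cccc(NS(=O)(=O)c2ccc(Cl)cc2)c1` gives 7.51

Compound 1 and compound 2 share one core, and compound 3 carries a different one. The difference between the two cores is nitro in place of hydrogen on an aromatic carbon; with it the measured step is a number 0.96 log units lower from compound 1 to compound 3 (beyond the scatter), so compound 3 stands lowest of the three, and its nearest neighbour in this assay is compound 1.

Compound 4 `O=[N+]([O-])c1cccc(NS(=O)(=O)c2ccc(Br)cc2)c1` has not yet been measured. Its difference from compound 3 is bromo in place of chloro on an aromatic carbon. The same change has already been made once among the measured compounds, from compound 1 to compound 2: bromo in place of chloro on an aromatic carbon. There the measured step was a number 0.03 log units higher from compound 1 to compound 2 (within the scatter). The surroundings of the changed position read the same in both pairs, so this is the same change, made here on the core of compound 3 instead of the core of compound 1.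

Among the compounds with values here, the step expected from compound 3 to compound 4 is therefore a number 0.03 log units higher from compound 3 to compound 4 (within the scatter), resting on the step of a number 0.03 log units higher from compound 1 to compound 2 (within the scatter) seen with the one earlier instance of this change. On that basis compound 4 is estimated to give 7.54 in this assay. Allowing for the usual spread of such measurements, compound 4 is expected to fall between 7.2 and 7.9.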

Compound 4, acid dissociation constant: 7.42
Estimate against measurement, compound 4: 0.12 log units above; low and high end bracket the measured number.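

In this assay, bromo in place of chloro gives a number 0.03 log units higher from compound 1 to compound 2 (within the scatter) on the core of compound 1 and a number 0.09 log units lower from compound 3 to compound 4 (within the scatter) on the core of compound 3, so the change stays within the scatter on both cores, and that small step carried over from one core to the other. The nitro step tells the same story from the other side: alongside a number 0.96 log units lower from compound 1 to compound 3 (beyond the scatter) with chloro there now stands a number 1.08 log units lower from compound 2 to compound 4 (beyond the scatter) with bromo, and both lie beyond the scatter, so the halogen swap leaves that separation between the cores in place. This rests on only two pairs, however, and steps this small cannot show whether the swap really moves the number in either direction or would stay this small on a third core, and nothing shown here offers an explanation for any of these steps.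

On these data alone, whether fluoro or iodo in place of chloro would also stay within the scatter remains open. So does how far the number in this assay would move with an amine, a carboxylic acid or a methoxy group in place of the nitro group.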